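Replacing the amide substituent on compound 3

The source may report more compounds than this note shows. Statements on the series, on what has been measured and on what is new or still open speak of the compounds shown alone.

Measured so far in an assay on lysate for inhibition of 6-phosphofructo-2-kinase/fructose-2,6-bisphosphatase 3 (Homo sapiens), with stated times of 0.5 min and 45 min; on this read-out lower numbers stand for stronger inhibition and higher numbers for weaker inhibition:
Compound 1 `CNS(=O)(=O)c1ccccc1Nc1cc(-c2ccc3ccn(C)c3c2)c2nccnc2c1` gives > 100000 nM, which is a limit of the assay rather than a number.
Compound 2 `Cn1ccc2ccc(-c3cc(Nc4ccccc4S(=O)(=O)N4CCOCC4)cc4nccnc34)cc21` gives 2640 nM.
Compound 3 `Cn1cc(NC(=O)c2ccncc2Nc2cc(-c3ccc4ccn(C)c4c3)c3nccnc3c2)cn1` gives 26500 nM.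

Compound 3 has the higher of the two numbers, and compound 2 is the nearer of the other values. Compound 4 `CC(=O)N1CC(CNC(=O)c2ccncc2Nc2cc(-c3ccc4ccn(C)c4c3)c3nccnc3c2)C1` differs from compound 3 by (1-acetylazetidin-3-yl)methyl in place of 1-methyl-1H-pyrazol-4-yl on an amide-type nitrogen. For the measured compounds named here, the only measured step, an at least 37-fold lower number from compound 1 to compound 2 (1.57 log units; beyond the scatter), concerns a change on a sulfonyl sulfur, a different place, so it gives no guidance on this change. No step beyond the scatter is therefore expected in this assay, in either direction. Compound 4 is estimated at 25000 nM, from 6000 nM to 100000 nM, an expected step of a 1.1-fold lower number from compound 3 to compound 4 (0.03 log units; within the scatter).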

Compound 4, half-maximal inhibitory concentration: > 100000 nM
Compound 4: no number, only a limit; the forecaster's own chance of this, stated with the estimate: 20%; at least 4.0-fold (0.60 log units) between middle value and limit.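

The only step shown at this amide nitrogen reveals that the group there matters: (1-acetylazetidin-3-yl)methyl in place of 1-methyl-1H-pyrazol-4-yl gives an at least 3.7-fold higher number from compound 3 to compound 4 (0.57 log units; beyond the scatter). Compound 4 gives > 100000 nM, which is a limit of the assay and not a number. The step is therefore only a minimum, and its full size cannot be read, because the value stands at a shared ceiling: the limit of > 100000 nM in this assay, at which 2 of the 4 values shown sit.

The compounds shown do not separate the effect of the four-membered ring from that of the acetyl group. As far as these compounds go, how a phenyl ring or a carboxylic acid on this nitrogen would read remains open.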